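A Methyl Added to Compound 3: Expected Cytotoxicity

A few compounds are considered here, and "the series" means these few. Any claim that something is new, unique, unknown or untested is made for them only; others in the source may bear on it.

Of the compounds shown here, three have so far been measured in a functional assay on HeLa cells (Homo sapiens) for cytotoxicity, read by CCK-8 assay, with a stated time of 24 h; on this read-out higher numbers stand for weaker inhibition and lower numbers for stronger inhibition.

Compound 1, `C=C1CCC(c2csc(/C=C(\C)C(N)=O)c2)CC1`: compound 1 gives 5010 nM.
Compound 2, `C/C(=C\c1cc(C2=CCCC2)co1)C(N)=O`: compound 2 gives 17600 nM.
Compound 3, `C/C(=C\c1cc(-c2ccccc2)cs1)C(N)=O`: compound 3 gives 12700 nM.

Among these three numbers compound 3 holds the second highest. Its nearest neighbour is compound 2, whose number lies within the usual scatter of that of compound 3, so no order between the two can be claimed. Compound 1 gives a lower number, and that gap lies beyond the scatter.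

Compound 4, `C/C(=C\c1cc(-c2ccc(C)cc2)cs1)C(N)=O`, has not yet been measured in this assay. It differs from compound 3 in one place: methyl in place of hydrogen on an aromatic carbon. Among the compounds with values here, no step between two measured compounds shows what such a change does, so the expectation rests on the small size of the change alone. In this assay the step from compound 3 to compound 4 is expected to stay within the scatter, with no direction claimed. Compound 4 is therefore estimated at 10000 nM, within a range from 4000 nM to 25000 nM. The expected step is a 1.3-fold lower number from compound 3 to compound 4 (0.10 log units; within the scatter).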

Compound 4, half-maximal inhibitory concentration: > 50000 nM
Compound 4: no number, only a limit; the forecaster's own chance of this, stated with the estimate: 10%; at least 5.0-fold (0.69 log units) between middle value and limit.
By their numbers in this assay, from the lowest: compound 1; then compounds 3 and 2 (each within the scatter of the next). At a limit, above all of these: compound 4.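

In this assay compound 4 gives > 50000 nM, which is a limit of the assay and not a number. This is the first step shown between two measured compounds that differ in one place, and it shows that this position is sensitive to a small change: methyl in place of hydrogen on an aromatic carbon, para to a large group, gives an at least 3.9-fold higher number from compound 3 to compound 4 (0.59 log units; beyond the scatter). How far the step reaches cannot be read, and compound 4 is the only compound shown at this limit: the limit of > 50000 nM in this assay, at which 1 of the 4 values shown sits.

The compounds shown leave open whether an amine, a hydroxyl or a carboxylic acid in this place would go the same way as methyl. They also leave open whether a methyl elsewhere on this six-membered ring would do the same.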